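The source may hold more compounds than are shown below. What is called first, only, known or untested is meant among the compounds shown, and "the series" means these compounds.

Measured compounds:
compound 1, `Cc1cc(C)cc(NC(=O)COc2cc(C)nc3ccc(F)cc23)c1`, 28000 nM in a physicochemical assay for solubility, in phosphate buffer, measured as kinetic solubility, with a stated time of 1 h, at pH 7.4; a higher number here means a more soluble compound, a lower number a less soluble compound
compound 2, `CCCc1cc(OCC(=O)Nc2cc(C)cc(C)c2)c2cc(OC)ccc2n1`, 12000 nM in this assay
compound 3, `COc1ccc2nc(C)cc(OCC(=O)Nc3ccc(Cl)cc3Cl)c2c1`, 20500 nM in this assay

Compound 3 sits between the other two on the numbers shown, but its gap to compound 1 and its gap to compound 2 are both within the usual scatter, so the three measured compounds cannot be told apart in this assay. Going by the values given here, no pair among them differs in only one place, so no single structural step has a measured size here.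

Compound 4, `COc1ccc2nc(C)cc(OCC(=O)NC3CONC3=O)c2c1`, is not yet measured. It differs from compound 3 at one place: a group of 6 heavy atoms (3 carbon, 1 nitrogen, 2 oxygen; one five-membered non-aromatic ring with 2 hetero atoms) in place of a group of 8 heavy atoms (6 carbon, 2 chlorine; one six-membered aromatic ring of carbon only), on an amide-type nitrogen The 2,4-dichlorophenyl group leaves and a five-membered non-aromatic ring with two hetero atoms, carrying one hydrogen-bond donor and two hydrogen-bond acceptors, enters on the amide-type nitrogen. Among the compounds with values here, with no measured step of this kind to lean on, the expectation rests on the change itself: a rise in solubility beyond the scatter is expected, with the step from compound 3 to compound 4 estimated at a 3.9-fold higher number from compound 3 to compound 4 (0.59 log units; beyond the scatter). Compound 4 is therefore expected to give about 80000 nM, within a range of 30000 nM to 220000 nM.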

Compound 4, solubility: >= 166000 nM
Compound 4: only a limit was reported; the forecaster's own chance of this, stated with the estimate: 15%; middle value at least 2.0-fold (0.31 log units) from the limit.
By their numbers in this assay, from the lowest: compounds 2, 3 and 1 (each within the scatter of the next, the first and the last beyond it). At a limit, above all of these: compound 4.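

On the amide-type nitrogen, a five-membered non-aromatic ring with 2 hetero atoms in place of 2,4-dichlorophenyl gives an at least 8.0-fold higher number from compound 3 to compound 4 (0.90 log units; beyond the scatter) in this assay. Going by these compounds alone, this is the first step with a measured size in the set, and it shows that this position can move the read-out beyond the scatter, something compounds 1, 2 and 3, which could not be told apart, gave no sign of. Compound 4 gives >= 166000 nM, which is a limit of the assay and not a number, so the full size of the step stays unknown: the limit of >= 166000 nM in this assay, at which 1 of the 4 values shown sits.

Going by these compounds, whether a cyclopentyl group or a carboxylic acid on the same nitrogen would give a step of like size remains open. Also open, on these data alone, is whether the ring's hetero atoms or the loss of the two chlorines carries the step.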